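The compounds below may be only part of what the source reports. "The series", "measured", "known", "first", "only" and "open" are said of these compounds alone.

In an ADME assay on HT-29 cells (Homo sapiens) for inhibition, read by MTT assay, with a stated time of 72 h (a lower number here means a stronger inhibitor, a higher number a weaker inhibitor), compound 3 `C/C(=N\Nc1ncc(Cl)c(Nc2cccc(NC(=O)/C=C/CN(C)C)c2)n1)c1ccc(F)cc1` gives 10200 nM, the highest of the three numbers measured here. Compound 1 `C=CC(=O)Nc1cccc(Nc2nc(N/N=C(\C)c3ccc(F)cc3)ncc2Cl)c1` gives 5050 nM, and compound 2 `CN(C)C/C=C/C(=O)Nc1cccc(Nc2nc(N/N=C/c3ccc(F)cc3)ncc2Cl)c1` gives 3300 nM. The two measured steps, a 2.0-fold higher number from compound 1 to compound 3 (0.31 log units; beyond the scatter) and a 3.1-fold higher number from compound 2 to compound 3 (0.49 log units; beyond the scatter), both concern other parts of the shared core and are modest in size. Compound 4 `C/C(=N\Nc1ncc(Cl)c(Nc2cccc(NC(=O)/C=C/CN(C)C)c2)n1)c1ccccn1` differs from compound 3 by pyridin-2-yl in place of 4-fluorophenyl on a carbon with a double bond to nitrogen. For the measured compounds named here, no measured step alters this aromatic ring, so the two steps offer no direct guide, and the change itself is small; on that basis no step beyond the scatter is expected, and the expected step is a 1.0-fold lower number from compound 3 to compound 4 (0.01 log units; within the scatter). Compound 4 is therefore estimated to give about 10000 nM in this assay, within a range from 4000 nM to 25000 nM.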

Compound 4, half-maximal inhibitory concentration: 120 nM
Estimate against measurement, compound 4: 83-fold (1.92 log units) above, and the stated range ends above it.
By their numbers in this assay, from the lowest: compound 4; then compounds 2 and 1 (each within the scatter of the next); then compound 3.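

In this assay, for the compounds shown here, the group on the carbon with a double bond to nitrogen proves a far more sensitive place than the earlier steps showed: pyridin-2-yl in place of 4-fluorophenyl gives an 85-fold lower number from compound 3 to compound 4 (1.93 log units; beyond the scatter). The change also stands out against the other measured comparison, a 28-fold lower number from compound 2 to compound 4 (1.44 log units; beyond the scatter), in which the whole group on a nitrogen on an aromatic ring differs. Nothing given here explains this large step.

Plain phenyl, pyridin-3-yl and pyridin-4-yl would show whether the ring nitrogen or the lost fluorine matters more. Going by these compounds, it also remains open whether the step holds with vinyl in place of 3-(dimethylamino)prop-1-en-1-yl on the carbonyl carbon.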